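A few compounds are considered here, and "the series" means these few. Any claim that something is new, unique, unknown or untested is made for them only; others in the source may bear on it.

Compound 1 `CC1=NC(C)=C([N+](=O)[O-])C(c2cccc(C(F)(F)F)n2)/C1=C(/O)OCCc1ccccc1` is the more potent of the two measured compounds: in a functional assay (muscle tissue) with Cavia porcellus as the target (a lower number here means a stronger inhibitor, a higher number a weaker inhibitor), compound 1 gives 1410 nM. Compound 2 `CC1=NC(C)=C([N+](=O)[O-])C(c2ncccc2[N+](=O)[O-])/C1=C(/O)OCCc1ccccc1` gives 77700 nM in this assay, and the step of a 55-fold higher number from compound 1 to compound 2 (1.74 log units; beyond the scatter) is large. Compound 3 `CC1=NC(C)=C([N+](=O)[O-])C(c2cccc(-c3ccccc3)n2)/C1=C(/O)OCCc1ccccc1` differs from compound 1 by phenyl in place of trifluoromethyl on an aromatic carbon. Among the compounds with values here, the only measured step exchanges the whole ring on the saturated ring carbon, whereas here just the trifluoromethyl on that ring changes, so it bears on this change only loosely. Compound 3 is therefore expected to stay close, at an estimated 3000 nM (from 700 nM to 15000 nM) in this assay, a step of a 2.1-fold higher number from compound 1 to compound 3 (0.33 log units; beyond the scatter).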

Compound 3, half-maximal inhibitory concentration: 8380 nM
For compound 3 the middle estimate is 2.8-fold (0.45 log units) below the measured one; low and high end bracket the measured number.
By their numbers in this assay, from the lowest: compound 1; then compound 3; then compound 2.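

In this assay, phenyl in place of trifluoromethyl on this aromatic carbon, next to the ring nitrogen, gives a 5.9-fold higher number from compound 1 to compound 3 (0.77 log units; beyond the scatter) and counts as a modest loss. The earlier step exchanged the whole ring, whereas this one shows that changing only the group on that ring also moves the number beyond the scatter. A ring at this carbon therefore costs potency relative to trifluoromethyl, but far less is learned about other groups here.

The compounds shown leave open how a methyl, an amine or a carboxylic acid on this carbon would compare. Nothing measured here gives a reason for the loss with phenyl.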